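The compounds below may be only part of what the source reports. "The series", "measured", "known", "first", "only" and "open" are said of these compounds alone.

Working notes on a small set of alkenyl thioethers bearing a chlorophenyl ketone. Two members have been measured in a functional assay on DU-145 cells (Homo sapiens) for inhibition, read by trypan blue exclusion, with a stated time of 96 h; a higher number here means a weaker inhibitor of growth, a lower number a stronger inhibitor of growth. Compound 1 `COc1ccccc1/C=C(/Sc1ccc(C)cc1)C(=O)c1ccc(Cl)cc1` gives 25000 nM in this assay. Compound 2 `Cc1ccc(CS/C(=C/c2sccc2C)C(=O)c2ccc(Cl)cc2)cc1` gives 10000 nM in this assay, the lower of the two numbers, and the gap between compound 2 and compound 1 is beyond the usual scatter; the two differ in more than one place, so the two values alone say nothing about which change carries the difference.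

The next compound, compound 3 `Cc1ccc(S/C(=C/c2sccc2C)C(=O)c2ccc(Cl)cc2)cc1`, keeps the rest of compound 2 unchanged and alters only the group on the sulfur: 4-methylphenyl in place of 4-methylbenzyl on a sulfur. Among the measured compounds shown here, the group that enters is the one already present on the sulfur of compound 1, but the rest of compound 1 is different, so no measured step isolates this change.

For compound 3 a modest move toward a higher number is expected, a 1.8-fold higher number from compound 2 to compound 3 (0.26 log units; within the scatter), within or just beyond the scatter, resting on compound 1 carrying the same sulfur group at 25000 nM. Compound 3 is therefore estimated at 18000 nM, with a range from 7000 nM to 45000 nM.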

Compound 3, concentration for 50% growth inhibition: 50000 nM
Compound 3: middle estimate off by 2.8-fold (0.44 log units), on the low side; the whole stated range lies below it.
By their numbers in this assay, from the lowest: compound 2; then compounds 1 and 3 (each within the scatter of the next).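

On a sulfur whose other neighbour is a double-bonded chain carbon, 4-methylphenyl in place of 4-methylbenzyl gives a 5.0-fold higher number from compound 2 to compound 3 (0.70 log units; beyond the scatter) in this assay and thus shows that this position responds to the change, which the first two values could not separate from the other differences between their compounds. With 4-methylphenyl on the sulfur, 3-methylthiophen-2-yl in place of 2-methoxyphenyl on a double-bonded chain carbon bound to a double-bonded chain carbon gives a 2.0-fold higher number from compound 1 to compound 3 (0.30 log units; within the scatter) and so shows no separation between those two compounds beyond the scatter. No measurement available here accounts for the response at the sulfur.

Going by these compounds, whether the same sulfur change would give a step of similar size on the core of compound 1 remains open, since only the 3-methylthiophen-2-yl compounds form a pair across it. Also open, on these data alone, is how a longer chain such as 2-(4-methylphenyl)ethyl, or a 4-aminophenyl group, would read on the same sulfur.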